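Series notes: hydrogen in place of methyl, compound 3 to compound 4

The source may report more compounds than this note shows. Statements on the series, on what has been measured and on what is new or still open speak of the compounds shown alone.

Measured in a functional assay on HeLa cells (Homo sapiens) for cytotoxicity, read by MTT assay, with a stated time of 72 h, tested at 30 uM; a higher number here means more inhibition of growth at the concentration tested, a lower number less inhibition of growth:
compound 1, `Cc1ccnc(/C(N)=N/NC(=S)N2CCCC2)c1`: 86.4%
compound 2, `Cc1cccc(/C(N)=N/NC(=S)N2CCCCC2)n1`: 83.5%
compound 3, `Cc1ccnc(/C(N)=N/NC(=S)N2CCN(c3ccccn3)CC2)c1`: 77%

All three numbers sit in one band. Compound 3 has the smallest number of the three, but its gap to compound 2 and its gap to compound 1 each lie within the scatter, so no ranking among the three can be read from these data. Going by the values given here, no pair of measured compounds differs in a single place, so no step size is available from the measured set.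

Compound 4, `N/C(=N\NC(=S)N1CCN(c2ccccn2)CC1)c1ccccn1`, has not yet been measured in this assay. It differs from compound 3 only in hydrogen in place of methyl on an aromatic carbon. Among the compounds with values here, since no measured step shows how such a change acts, the expectation rests on the narrow band of the three numbers alone. The step from compound 3 to compound 4 is expected to be small, a number 2 percentage points lower from compound 3 to compound 4 (within the scatter), not clearly beyond the scatter in either direction. Compound 4 is therefore estimated at 75%, with a range from 60% to 88%.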

Compound 4, percent growth inhibition at one concentration: 78.9%
The estimate for compound 4 lay 3.9 percentage points below the measured number; the range from low to high includes it.
By their numbers in this assay, from the lowest: compounds 3, 4, 2 and 1 (each within the scatter of the next).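

Going by these compounds alone, the step of a number 1.9 percentage points higher from compound 3 to compound 4 (within the scatter) in this assay is the first single-place comparison, and it concerns the change from 4-methylpyridin-2-yl to pyridin-2-yl. At this position, on an aromatic carbon opposite the ring nitrogen, the methyl is not needed to keep compound 4 in the same band as compound 3 at the concentration tested. No measurement at hand bears on the cause of a step of this size.

On these data alone, whether an amine, a methoxy group or a carboxylic acid at this position would move the number beyond the scatter remains open. So does whether hydrogen in place of methyl gives a similar step in compounds carrying the other groups of compound 1 or compound 2, as this single pair cannot show it.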